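Pyridinyl Benzamides as Weak Inhibitors of a Steroidogenic Enzyme

A few compounds are considered here, and "the series" means these few. Any claim that something is new, unique, unknown or untested is made for them only; others in the source may bear on it.

The compounds measured so far:
Compound 1, `Cc1cc(Cl)ccc1C(=O)N(C)c1cccnc1`, in an ADME assay on cells for inhibition of cytochrome P450 11B1, mitochondrial (Homo sapiens), read by HTRF (a higher number here means a weaker inhibitor, a lower number a stronger inhibitor), gives > 3000 nM, which is a limit of the assay and not a number.
Compound 2, `O=C(Nc1cccnc1)c1ccc(Cl)cc1F`, in this assay gives > 3000 nM, again a limit of the assay.
Compound 3, `CC(=O)N[C@@H]1CCCc2c1cncc2N1C(=O)c2ccc(Cl)cc2[C@H]1C1CC1`, in this assay gives 22800 nM.

Compound 2 therefore stands only at a limit: in this assay it shows no measurable inhibition within the tested range, and compound 1 sits at the same limit (the limit of > 3000 nM in this assay, at which 2 of the 3 values shown sit). Among the compounds with values here, compound 3, of a different build, is the one compound with a numerical value, and that value lies at the weak end of the assay.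

Compound 4, `Cc1cc(Cl)ccc1C(=O)Nc1cccnc1`, has not yet been measured. It is derived from compound 2 by one change: methyl in place of fluoro on an aromatic carbon. Within the data shown here, no step between measured compounds is known, so nothing tells how this change moves the read-out. Given that compound 2 gives only the limit > 3000 nM, and that compound 1, which also carries the methyl and chloro pattern, gives only a limit too, the expected step from compound 2 to compound 4 is a step that the limit leaves unreadable from compound 2 to compound 4, likely none beyond the scatter. Compound 4 is estimated at 10000 nM, within 3000 nM to 40000 nM, most probably reported again as a limit.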

Compound 4, half-maximal inhibitory concentration: > 3000 nM
Compound 4: no number, only a limit; the forecaster's own chance of this, stated with the estimate: 65%; the middle value lies beyond the limit too.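

No step among compound 1, compound 2 and compound 4 can be read, because all three stop at the same limit: the limit of > 3000 nM in this assay, at which 3 of the 4 values shown sit.

The compounds shown leave open whether methyl in place of fluoro on an aromatic carbon, or hydrogen in place of methyl on an amide-type nitrogen, changes the read-out in this assay at all.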